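The compounds below may be only part of what the source reports. "The series", "measured", "known", "first", "only" and "open" are said of these compounds alone.

Of the compounds shown here, three sharing one core have been tested in a functional assay on CCRF-CEM cells (Homo sapiens) for cytotoxicity; a higher number here means that more compound is tolerated, a lower number that less compound is tolerated. Compound 1 `O=C1Nc2ccccc2/C1=N\c1nc(NC2CC2)c2ncn(C3C=CC(CO)C3)c2n1` gives 48000 nM, and compound 3 `OCC1C=CC(n2cnc3c(NC4CC4)nc(/N=C(\c4ccccc4)c4ccc(Br)cc4)nc32)C1` gives 45000 nM. Compound 2 `Cc1ccc(/C=N/c2nc(NC3CC3)c3ncn(C4C=CC(CO)C4)c3n2)cc1` returns only a limit, > 100000 nM, and no number. It thus stands at the limit of > 100000 nM in this assay, at which 1 of the 3 values shown sits.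

Compound 4 `O=[N+]([O-])c1ccc(/C=N/c2nc(NC3CC3)c3ncn(C4C=CC(CO)C4)c3n2)cc1` carries nitro in place of methyl on an aromatic carbon, para to a large group, turning 4-methylphenyl into 4-nitrophenyl: nitro in place of methyl on an aromatic carbon. Among the compounds with values here, no measured pair tests this change. A modest step, an at least 1.4-fold lower number from compound 2 to compound 4 (0.15 log units; that floor lies within the scatter), is expected in this assay, towards less compound tolerated, with compound 1 at 48000 nM as the nearest numeric guide. For compound 4 the estimated value is 70000 nM, with an expected range of 25000 nM to 100000 nM.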

Compound 4, half-maximal cytotoxic concentration: 12000 nM
Compound 4: the middle estimate sits 5.8-fold (0.77 log units) above what was measured; the whole stated range lies above it.
By their numbers in this assay, from the lowest: compound 4; then compounds 3 and 1 (each within the scatter of the next). At a limit, above all of these: compound 2.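

In this assay, within the data shown here, the group on this aromatic carbon, para to a large group, proves to matter: nitro in place of methyl gives an at least 8.3-fold lower number from compound 2 to compound 4 (0.92 log units; beyond the scatter), the only step here between compounds that differ in one place. Compound 2 gives a limit and not a number: the limit of > 100000 nM in this assay, at which 1 of the 4 values shown sits. As far as these compounds go, the full size of the step therefore stays unknown. From the compounds shown here alone, whether an amine or a nitrile on the same carbon would also lower the number remains open, as does whether a carboxylic acid there would.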